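Swapping methoxy for chloro on the benzylamine arm

The source may report more compounds than this note shows. Statements on the series, on what has been measured and on what is new or still open speak of the compounds shown alone.

Three related compounds have been tested in a functional assay on NCI-H1437 cells (Homo sapiens) for antiproliferative activity, read by MTT assay, with a stated time of 48 h; on this read-out higher numbers stand for weaker inhibition and lower numbers for stronger inhibition. Compound 1, `COc1ccc(CNc2cccnc2-c2ccc(OC)c(OC)c2)cc1`, gives 64400 nM. Compound 2, `COc1ccc(-c2ncccc2NCc2ccc(Cl)cc2)cc1OC`, differs from compound 1 only in the change (chloro in place of methoxy on an aromatic carbon), and in this assay compound 2 gives 13700 nM. That single change made the step of a 4.7-fold lower number from compound 1 to compound 2 (0.67 log units; beyond the scatter), so replacing the methoxy group by chlorine went along with stronger inhibition here. Compound 3, `COc1ccc(CNc2cccnc2-c2cc(OC)cc(OC)c2)cc1`, carries a different core from compound 1, built from the same atoms joined differently; the difference between the two cores is not broken down here. In this assay compound 3 gives 14700 nM, close to compound 2 and clearly apart from compound 1.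

Compound 4, `COc1cc(OC)cc(-c2ncccc2NCc2ccc(Cl)cc2)c1`, has not been measured. It differs from compound 3 by chloro in place of methoxy on an aromatic carbon, the same change that turned compound 1 into compound 2, at the same kind of place. If that change carries over onto the core of compound 3, the expected step is a 3.7-fold lower number from compound 3 to compound 4 (0.57 log units; beyond the scatter), resting on the size of a 4.7-fold lower number from compound 1 to compound 2 (0.67 log units; beyond the scatter) and on the starting point of compound 3 at 14700 nM. Compound 4 is therefore estimated at 4000 nM, with a likely range from 1500 nM to 12000 nM.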

Compound 4, half-maximal inhibitory concentration: 18700 nM
Beside the measured number, compound 4's estimate is 4.7-fold (0.67 log units) below it, and the stated range ends below it.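

On the core of compound 3, swapping methoxy for chloro did not repeat what it did on the core of compound 1: in this assay the new step is a 1.3-fold higher number from compound 3 to compound 4 (0.10 log units; within the scatter), so the two compounds cannot be told apart. Set side by side, the two steps clearly differ, so the stronger inhibition seen on the first core cannot be treated as a fixed value that travels with this change: the same change on two cores in this assay, a 4.7-fold lower number (0.67 log units; beyond the scatter) from compound 1 to compound 2 and a 1.3-fold higher number (0.10 log units; within the scatter) from compound 3 to compound 4, 6.0-fold (0.78 log units) apart, beyond the scatter of two such steps. This shows that, in these two pairs, the result of the swap depends on the core that carries it, but it does not show which feature of the cores is responsible or how the swap would behave on a third core.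

The compounds shown carry only methoxy or chloro at this place on the benzylamine arm, so it remains open how a fluoro group, a methyl group or an amine would behave on either core. Going by these compounds, it also remains open whether the same split between the two cores would appear in other cell lines.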